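Thiophen-2-yl to furan-2-yl: a small expected step

A few compounds are considered here, and "the series" means these few. Any claim that something is new, unique, unknown or untested is made for them only; others in the source may bear on it.

Values in a physicochemical assay for solubility, at pH 7; on this read-out lower numbers stand for lower solubility and higher numbers for higher solubility:
Compound 1 `CN1CCC(C(=O)N2Cc3c(NC(=O)C4CC4)n[nH]c3C2(C)C)CC1` gives > 225000 nM, a limit of the assay and not a number.
Compound 2 `CN1CCC(C(=O)N2Cc3c(NC(=O)c4ccsc4)n[nH]c3C2(C)C)CC1` gives > 225000 nM, also a limit of the assay.
Compound 3 `CN1CCC(C(=O)N2Cc3c(NC(=O)c4cccs4)n[nH]c3C2(C)C)CC1` gives 155000 nM.

For the measured compounds named here, compound 3 carries the only actual number in this small set. The other two results are the limit of > 225000 nM in this assay, at which 2 of the 3 values shown sit. The unmeasured compound 4 `CN1CCC(C(=O)N2Cc3c(NC(=O)c4ccco4)n[nH]c3C2(C)C)CC1` differs from compound 3 in one group, with furan-2-yl in place of thiophen-2-yl on a carbonyl carbon. Both groups are a five-membered aromatic ring with 1 hetero atom. Going by the values given here, two measured steps bear on this change, since both swap the group at that same place: an at least 1.4-fold lower number from compound 2 to compound 3 (0.16 log units; that floor lies within the scatter) and an at least 1.4-fold lower number from compound 1 to compound 3 (0.16 log units; that floor lies within the scatter). Neither step is shown to exceed the scatter, so they give no firm size to carry over. No step beyond the scatter is therefore expected in this assay, and no firm direction either. The expected step is a 1.3-fold higher number from compound 3 to compound 4 (0.11 log units; within the scatter). The estimated value for compound 4 is 200000 nM, with an expected range from 110000 nM to 300000 nM.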

Compound 4, solubility: > 225000 nM
Compound 4: a limit, no number (the forecaster's own chance of this, stated with the estimate: 40%); at least 1.1-fold (0.05 log units) between middle value and limit.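

In this assay, going by these compounds, furan-2-yl in place of thiophen-2-yl on a carbonyl carbon gives an at least 1.4-fold higher number from compound 3 to compound 4 (0.16 log units; that floor lies within the scatter), so the true size of this swap stays unknown and could be larger than that floor. The steps to compound 4 from compound 1 and from compound 2 cannot be read, as both ends of each are limits. Compound 3 is now the only compound shown with an actual number, and the other three share one limit: the limit of > 225000 nM in this assay, at which 3 of the 4 values shown sit.

With so many results at that limit, the cyclopropyl, thiophen-3-yl and furan-2-yl groups cannot be ranked against one another. The compounds shown also leave open what an amine, a carboxylic acid or a longer chain on that carbonyl carbon would give in this assay.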